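Alkoxy trimming on the aromatic ring: isopropoxy to methoxy

The source may hold more compounds than are shown below. What is called first, only, known or untested is meant among the compounds shown, and "the series" means these compounds.

Working notes on a small set of bridged bicyclic amines carrying an aromatic ring, measured in an in vitro assay on SH-EP1 cells for displacement of a labelled ligand from Neuronal acetylcholine receptor; alpha4/beta2 (Homo sapiens); a higher number here means a weaker inhibitor, a lower number a stronger inhibitor. Compound 1 `C1=C(c2cncnc2)CC2CNCC1C2` gives 0.2 nM in this assay. Compound 2 `CC(C)Oc1cncc(C2=CC3CNCC(C2)C3)c1` gives 0.26 nM, the second highest of the three numbers; its nearest neighbour is compound 1, and the two values lie within the scatter of each other, while its furthest is compound 3 `CC(C)Oc1cncc(C2=CC3CC(C2)CN(C)C3)c1`, which gives 2.2 nM. Within the data shown here, the only step that differs in one place, an 8.5-fold higher number from compound 2 to compound 3 (0.93 log units; beyond the scatter), concerns methyl in place of hydrogen on an amine nitrogen in a ring and is modest in size.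

Compound 4 `COc1cncc(C2=CC3CNCC(C2)C3)c1` has not yet been measured. Against compound 2 it shows (methyl in place of isopropyl on an oxygen on an aromatic ring). Among the measured compounds shown here, no measured step touches the alkoxy group on the aromatic ring, so the change from compound 2 to compound 3 does not bear on it directly; the values of compound 1 and compound 2 show that a rather different aromatic portion gave a number within the scatter. For compound 4 the step of a 1.2-fold higher number from compound 2 to compound 4 (0.06 log units; within the scatter) is therefore expected to stay within the scatter, with no clear direction. Compound 4 is estimated at 0.3 nM, in a range from 0.1 nM to 1 nM.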

Compound 4, inhibition constant: 0.3 nM
Beside the measured number, compound 4's estimate shows no gap at the digits printed, and the stated range covers the measured number.
By their numbers in this assay, from the lowest: compounds 1, 2 and 4 (each within the scatter of the next); then compound 3.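

In this assay, among these compounds, the alkoxy group on the aromatic ring is now covered by a measured step for the first time: isopropoxy to methoxy gives (a 1.2-fold higher number from compound 2 to compound 4 (0.06 log units; within the scatter)), so the shorter group leaves the number within the scatter of the isopropoxy compound. Among the compounds shown here, the only earlier step, at the amine nitrogen in a ring (an 8.5-fold higher number from compound 2 to compound 3 (0.93 log units; beyond the scatter)), lies beyond the scatter, so within this small set the change on the oxygen and the change on the nitrogen do not read alike: the first leaves the number in place, and the second raises it. Nothing measured on these compounds bears on why the number holds across this change.

From the compounds shown here alone, at this oxygen only isopropyl and methyl are covered, so it remains open whether a longer chain such as n-butyl, a cyclopropylmethyl group or a chain ending in an amine would also stay within the scatter, or whether a fluorine or an amine in place of the whole alkoxy group would do so. Going by these compounds, it is also open whether methyl on the amine nitrogen would raise the number as much with methoxy on the aromatic ring as it does with isopropoxy.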